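The source may report more compounds than this note shows. Statements on the series, on what has been measured and on what is new or still open speak of the compounds shown alone.

Series notes, read in a functional assay for inhibition; on this read-out lower numbers stand for stronger inhibition and higher numbers for weaker inhibition: compound 1 `CC(C)(C)c1cc(-c2cc(=O)c3ccc(OCc4ccc(Cl)cc4)cc3o2)cc(C(C)(C)C)c1O` gives 7000 nM and compound 2 `CN(C)CCCOc1ccc2c(=O)cc(-c3cc(C(C)(C)C)c(O)c(C(C)(C)C)c3)oc2c1` gives 700 nM as the lower of the two numbers so far. Among the measured compounds shown here, the only measured step is a 10-fold lower number from compound 1 to compound 2 (1.00 log units; beyond the scatter) on going from 4-chlorophenyl to 2-(dimethylamino)ethyl on the saturated chain carbon bound to the oxygen. Compound 3 `CC(C)(C)c1cc(-c2cc(=O)c3ccccc3o2)cc(C(C)(C)C)c1O` follows from compound 2 by hydrogen in place of 3-(dimethylamino)propoxy on an aromatic carbon and so carries hydrogen in place of 3-(dimethylamino)propoxy on an aromatic carbon. For the measured compounds named here, no measured compound has hydrogen at this place, so the one measured step bears on the change only indirectly. It does show that changes in this substituent can move the number beyond the scatter. With compound 2 at 700 nM holding the lower number, a rise is the likelier direction, and compound 1 at 7000 nM serves as a rough upper reference. In this assay the expected change is a 4.3-fold higher number from compound 2 to compound 3 (0.63 log units; beyond the scatter) toward weaker inhibition, somewhat smaller than the measured step. Compound 3 is estimated at 3000 nM with an expected range from 800 nM to 12000 nM on this sparse evidence.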

Compound 3, half-maximal inhibitory concentration: 3000 nM
The estimate for compound 3 equals the measured number at the digits printed; measured number inside the range.
By their numbers in this assay, from the lowest: compound 2; then compound 3; then compound 1.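

Hydrogen on this aromatic carbon gives the series its first reference point, and in this assay the replacement of 3-(dimethylamino)propoxy by hydrogen is a 4.3-fold higher number from compound 2 to compound 3 (0.63 log units; beyond the scatter) and places the 3-(dimethylamino)propoxy compound ahead of the unsubstituted one. The replacement of (4-chlorobenzyl)oxy by hydrogen runs the opposite way, as a 2.3-fold lower number from compound 1 to compound 3 (0.37 log units; beyond the scatter) and so the two ether substituents fall on opposite sides of hydrogen, each beyond the scatter, which means that substitution at this carbon can either strengthen or weaken inhibition depending on the group. No supporting data accompany these numbers to account for the split.

From the compounds shown here alone, it remains open whether the gain over hydrogen belongs to the terminal dimethylamino group or to the chain itself, a question that a plain propoxy chain without an amine, a morpholine at the chain end, or a longer chain ending in dimethylamino would help to settle. Going by these compounds, it is equally open whether the loss with (4-chlorobenzyl)oxy needs the chlorine or the whole benzyl ring, and an unsubstituted benzyloxy or a small methoxy on this carbon would bear on that.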